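A 3-Nitrophenyl Group Replaces 2-Methylprop-1-en-1-yl

The source may report more compounds than this note shows. Statements on the series, on what has been measured and on what is new or still open speak of the compounds shown alone.

Measured so far in a functional assay on WRL68 cells (Homo sapiens) for cytotoxicity, read by colony formation; a lower number here means a stronger inhibitor, a higher number a weaker inhibitor:
compound 1 `CCCCCCCCCCCC(=O)OC[C@H]1O[C@@H](O[C@@H]2OC=C(C(=O)OC)[C@H]3C[C@H](OC(C)=O)[C@H](C)[C@@H]23)[C@H](OC(C)=O)[C@@H](OC(C)=O)[C@@H]1OC(C)=O` gives 2.62 ug/mL
compound 2 `COC(=O)C1=CO[C@@H](O[C@@H]2O[C@H](COC(=O)C=C(C)C)[C@@H](OC(C)=O)[C@H](OC(C)=O)[C@H]2OC(C)=O)[C@@H]2[C@@H](C)[C@@H](OC(C)=O)C[C@H]12` gives 3.86 ug/mL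

Within the data shown here, the one step between these two (a 1.5-fold higher number from compound 1 to compound 2 (0.17 log units; within the scatter)) leaves compound 2 level with compound 1, the only other compound measured. Compound 3 `COC(=O)C1=CO[C@@H](O[C@@H]2O[C@H](COC(=O)c3cccc([N+](=O)[O-])c3)[C@@H](OC(C)=O)[C@H](OC(C)=O)[C@H]2OC(C)=O)[C@@H]2[C@@H](C)[C@@H](OC(C)=O)C[C@H]12` keeps the shared core and carries 3-nitrophenyl in place of 2-methylprop-1-en-1-yl on a carbonyl carbon. Among the measured compounds shown here, only one measured step bears on this place: the exchange of undecyl for 2-methylprop-1-en-1-yl on a carbonyl carbon (a 1.5-fold higher number from compound 1 to compound 2 (0.17 log units; within the scatter)). Two very different groups there thus gave no change beyond the scatter. For the measured compounds named here, no compound with an aromatic ring at this place has been measured, so this single step is thin guidance. No step beyond the scatter is expected in this assay, and no direction can be named. The expected step is small (a 1.1-fold lower number from compound 2 to compound 3 (0.06 log units; within the scatter)). Compound 3 is estimated at 3.4 ug/mL (expected range 1.3 ug/mL to 8.5 ug/mL).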

Compound 3, half-maximal inhibitory concentration: 6.5 ug/mL
Estimate against measurement, compound 3: 1.9-fold (0.28 log units) below; measured number inside the range.
By their numbers in this assay, from the lowest: compounds 1, 2 and 3 (each within the scatter of the next, the first and the last beyond it).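

In this assay, 3-nitrophenyl brings an aromatic ring to this place on the carbonyl carbon among the compounds shown, and its exchange for 2-methylprop-1-en-1-yl gives a 1.7-fold higher number from compound 2 to compound 3 (0.23 log units; within the scatter) and so does not separate the two compounds. Set against undecyl, the same group gives a 2.5-fold higher number from compound 1 to compound 3 (0.39 log units; beyond the scatter) and is the first exchange at this place to pass the scatter, although only modestly, which shows that the place is not wholly indifferent to the group it carries, even though neither single exchange involving 2-methylprop-1-en-1-yl resolves anything. No measurement shown here explains this step.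

The compounds shown leave open whether the difference from undecyl belongs to the aromatic ring or to its nitro group, which a plain phenyl ring, or a ring carrying an amine or a carboxylic acid in place of the nitro group, could begin to separate. They also leave open how chains shorter or longer than undecyl would stand at this place, and whether the modest step would hold across more than this one pair.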